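A few compounds are considered here, and "the series" means these few. Any claim that something is new, unique, unknown or untested is made for them only; others in the source may bear on it.

Compound 1 `O=C(NCc1ccccc1)c1csc(-c2c[nH]c3ccccc23)n1` in a functional assay on LNCaP cells (Homo sapiens) for cytotoxicity, read by MTT assay, with a stated time of 48 h, in the presence of a further agent that is not named here; on this read-out lower numbers stand for stronger inhibition and higher numbers for weaker inhibition: > 100000 nM, a limit of the assay rather than a number.
Compound 2 `O=C(Nc1ccccc1)c1csc(-c2cn(Cc3ccc(Cl)cc3)c3ccccc23)n1` in this assay: 68900 nM.

Compound 2 holds the only number shown in this assay; the other entry is the limit (the limit of > 100000 nM in this assay, at which 1 of the 2 values shown sits). Compound 3 `O=C(Nc1ccccc1)c1csc(-c2c[nH]c3ccccc23)n1` differs from compound 2 by hydrogen in place of 4-chlorobenzyl on an aromatic nitrogen. Among the compounds with values here, no step between measured compounds is available. Compound 1 carries the same hydrogen on that nitrogen and gives > 100000 nM, a limit. The step is therefore expected to be a 2.2-fold higher number from compound 2 to compound 3 (0.34 log units; beyond the scatter), weaker beyond the scatter. Compound 3 is estimated at 150000 nM, in the range 50000 nM to 500000 nM.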

Compound 3, half-maximal inhibitory concentration: > 100000 nM
Compound 3: no number, only a limit (the forecaster's own chance of this, stated with the estimate: 55%); the middle value lies beyond the limit too.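

Hydrogen in place of 4-chlorobenzyl on the aromatic nitrogen gives an at least 1.4-fold higher number from compound 2 to compound 3 (0.16 log units; that floor lies within the scatter). Within the data shown here, compound 3 is recorded only as a limit of the assay, so the size of this change stays bounded from one side, and the only measured number in this assay remains that of the compound carrying 4-chlorobenzyl. The step between compound 1 and compound 3, phenyl in place of benzyl on the amide-type nitrogen, cannot be read, and the series offers little resolution: the limit of > 100000 nM in this assay, at which 2 of the 3 values shown sit.

Open, from the compounds shown here alone, is how a plain benzyl, a methyl or an aminoethyl chain on that nitrogen would compare. Also open, going by these compounds, is whether the chlorine contributes to the value of compound 2.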